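A new aromatic group on compound 1

The compounds below may be only part of what the source reports. "The series", "measured", "known", "first", "only" and "open" are said of these compounds alone.

Among the compounds with values here, in a functional assay on DU-145 cells (Homo sapiens) for antiproliferative activity, read by propidium iodide staining, with a stated time of 96 h (a lower number here means a stronger inhibitor, a higher number a weaker inhibitor), compound 1 `CC(O)(COc1ccccc1C(F)(F)F)C(=O)Nc1ccc(S(F)(F)(F)(F)F)cc1` gives 7100 nM, the lowest number of the three measured so far and so the strongest inhibitor among them. Compound 2 `CC(O)(COc1ccccc1OC(F)(F)F)C(=O)Nc1ccc(S(F)(F)(F)(F)F)cc1` gives 16800 nM, and compound 3 `CC(O)(COc1ccc(C#N)cc1C(F)(F)F)C(=O)Nc1ccc(S(F)(F)(F)(F)F)cc1` gives 21200 nM.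

Compound 4 `CC(O)(COc1ccc(C#N)c(F)c1)C(=O)Nc1ccc(S(F)(F)(F)(F)F)cc1` has not yet been measured. It carries 4-cyano-3-fluorophenyl in place of 2-(trifluoromethyl)phenyl on an oxygen on a saturated carbon.

Two measured changes offer some guidance, though neither matches this one. Trifluoromethoxy in place of trifluoromethyl gave a 2.4-fold higher number from compound 1 to compound 2 (0.37 log units; beyond the scatter), and cyano in place of hydrogen gave a 3.0-fold higher number from compound 1 to compound 3 (0.48 log units; beyond the scatter). Both steps are modest, lie beyond the usual scatter and point towards weaker inhibition. Within the data shown here, no measured compound carries 4-cyano-3-fluorophenyl, so any forecast stays loose.

A modest move towards weaker inhibition is therefore expected in this assay. The expected step is a 2.1-fold higher number from compound 1 to compound 4 (0.32 log units; beyond the scatter). The estimated value for compound 4 is 15000 nM, with a likely range of 5000 nM to 40000 nM.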

Compound 4, half-maximal inhibitory concentration: 30400 nM
For compound 4 the middle estimate is 2.0-fold (0.31 log units) below the measured one, and the stated range covers the measured number.
By their numbers in this assay, from the lowest: compound 1; then compounds 2, 3 and 4 (each within the scatter of the next).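

In this assay, putting 4-cyano-3-fluorophenyl in place of 2-(trifluoromethyl)phenyl on an oxygen on a saturated carbon gives a 4.3-fold higher number from compound 1 to compound 4 (0.63 log units; beyond the scatter). Here the whole aromatic group is exchanged rather than a single group on it, and the number still moves the same way: all three changes shown from compound 1 lead towards weaker inhibition, and none goes against this. Nothing measured here accounts for the shift.

Because this swap removes the trifluoromethyl and adds a nitrile and a fluorine together, the compounds shown cannot say what each change contributes alone. They also leave open whether a plain phenyl, or a ring carrying a single fluorine or a methoxy group, would give a number lower than that of compound 1.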